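Replacing a Dimethylcarbamoyl Group with a 2-Carboxyethyl Chain

A few compounds are considered here, and "the series" means these few. Any claim that something is new, unique, unknown or untested is made for them only; others in the source may bear on it.

Of the compounds shown here, two sharing one core have been measured in a functional assay with Oryctolagus cuniculus as the target; a higher number here means a weaker inhibitor, a lower number a stronger inhibitor. Compound 1 `CNC(=N)Nc1nc(-c2ccc(OC)cc2)c(-c2ccc(OC)cc2)s1` in this assay gives 62 nM. Compound 2 `COc1ccc(-c2nc(C(=O)N(C)C)sc2-c2ccc(OC)cc2)cc1` differs from compound 1 in a single group on the core. In this assay compound 2 reaches only a limit of the assay, < 100 nM, not a number. The step that the limit leaves unreadable from compound 1 to compound 2 therefore has no readable size, since (the limit of < 100 nM in this assay, at which 1 of the 2 values shown sits).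

Compound 3 `COc1ccc(-c2nc(CCC(=O)O)sc2-c2ccc(OC)cc2)cc1` is the compound still to be measured. It differs from compound 2 in one place: 2-carboxyethyl in place of dimethylcarbamoyl on an aromatic carbon. Among the compounds with values here, no measured step involves a 2-carboxyethyl group, and the only step between measured compounds is unreadable, so no measured step bears on this change and neither its direction nor its size can be drawn from the numbers at hand. Taking compound 2 as the starting point and allowing wide uncertainty, compound 3 is expected to give 150 nM in this assay, with a likely range from 30 nM to 800 nM. This estimate corresponds to an expected step of an at least 1.5-fold higher number from compound 2 to compound 3 (0.17 log units; that floor lies within the scatter) in this assay.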

Compound 3, half-maximal inhibitory concentration: < 100 nM
Compound 3 gave a limit, no number; the forecaster's own chance of this, stated with the estimate: 30%; at least 1.5-fold (0.17 log units) between middle value and limit.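

In this assay compound 3 reaches only a limit of the assay, < 100 nM, so no step from compound 1 or compound 2 to compound 3 can be read: the limit of < 100 nM in this assay, at which 2 of the 3 values shown sit.

As far as these compounds go, whether 2-carboxyethyl or dimethylcarbamoyl gives the stronger inhibitor, by how much, and how compound 2 and compound 3 truly compare with compound 1 all remain open.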